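Compound 3 in the antiproliferative series: amide group swap

A few compounds are considered here, and "the series" means these few. Any claim that something is new, unique, unknown or untested is made for them only; others in the source may bear on it.

Compound 1 `CCN1CCN(c2cc(C)c3cc(NC(=O)c4ccc[nH]4)ccc3n2)CC1`: 14700 nM
Compound 2 `CCN1CCN(c2cc(C)c3cc(NC(=O)c4ccccc4Cl)ccc3n2)CC1`: > 50000 nM

Both values come from a functional assay on MCF7 cells (Homo sapiens) for antiproliferative activity, read by MTT assay, with a stated time of 72 h; on this read-out lower numbers stand for stronger inhibition and higher numbers for weaker inhibition. Compound 2 sits at the limit of > 50000 nM in this assay, at which 1 of the 2 values shown sits, which is a limit and not a number. The next structure is compound 3 `CCN1CCN(c2cc(C)c3cc(NC(=O)c4ccc5ccccc5n4)ccc3n2)CC1`, and the change is quinolin-2-yl in place of 2-chlorophenyl on a carbonyl carbon.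

Going by the values given here, one measured step bears on this place: an at least 3.4-fold higher number from compound 1 to compound 2 (0.53 log units; beyond the scatter), with 2-chlorophenyl in place of 1H-pyrrol-2-yl on a carbonyl carbon. Among the compounds with values here, that step ends at the limit, so its full size stays open, and no measured compound carries quinolin-2-yl. Compound 1, at 14700 nM, shows that a change at this place can bring a measurable value. A small to modest step towards lower numbers in this assay is therefore expected, though compound 3 may also end at the limit.

Compound 3 is estimated at 30000 nM, with an expected range of 12000 nM to 50000 nM. This estimate means an expected at least 1.6-fold lower number from compound 2 to compound 3 (0.22 log units; that floor lies within the scatter).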

Compound 3, half-maximal inhibitory concentration: 7060 nM
The estimate for compound 3 lay 4.2-fold (0.63 log units) above the measured number, outside the stated range (below it).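

In this assay, quinolin-2-yl on this carbonyl carbon gives an at least 7.0-fold lower number from compound 2 to compound 3 (0.85 log units; beyond the scatter), so replacing 2-chlorophenyl recovers measurable activity and more. Compound 2 has a limit and not a number, which leaves the upper size of that step open: the limit of > 50000 nM in this assay, at which 1 of the 3 values shown sits. Quinolin-2-yl also improves on the group in compound 1, with a 2.1-fold lower number from compound 1 to compound 3 (0.32 log units; beyond the scatter), making compound 3 the most potent of the three; with 0 hydrogen-bond donors on quinolin-2-yl, a donor on this group is not required for a measurable value in this series.

Quinolin-2-yl differs from 2-chlorophenyl at once in its second aromatic ring, in its ring nitrogen with 1 hydrogen-bond acceptor, and in the loss of chlorine, and the compounds shown do not tell these contributions apart. From the compounds shown here alone, how a pyridin-2-yl group, which keeps the ring nitrogen with a single ring, or a naphthalen-2-yl group, which keeps both rings with carbon only, would stand on this carbonyl carbon remains open.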